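The source may hold more compounds than are shown below. What is called first, only, known or untested is meant among the compounds shown, and "the series" means these compounds.

Measured in an ADME assay on the whole organism (strain 129/SvEvBrd x C57BL/6) for metabolic stability, with Mus musculus as the target; on this read-out lower numbers stand for a shorter-lived compound and higher numbers for a longer-lived compound:
Compound 1 `CC(=O)c1cccc([C@@H](O)[C@H](O)[C@H](O)CO)n1`: 2.1 h
Compound 2 `CN(C)C(=O)c1nc([C@@H](O)[C@H](O)[C@H](O)CO)c[nH]1`: 4 h
Compound 3 `OC[C@@H](O)[C@@H](O)[C@H](O)c1c[nH]c(-c2ncn(Cc3ccccc3)n2)n1`: 2.4 h

Compound 2, at 4 h, gives the highest number of the three, yet its gaps to compound 1 and compound 3 both lie within the usual scatter. Compound 4 `OC[C@@H](O)[C@@H](O)[C@H](O)c1c[nH]c(-c2ncc[nH]2)n1` differs from compound 2 by having 1H-imidazol-2-yl in place of dimethylcarbamoyl on an aromatic carbon. Among the measured compounds shown here, no measured pair shows this change directly. Compound 3, which also carries a ring-containing group at that place, gives 2.4 h, so no step beyond the scatter is expected in this assay. The expected step is a 1.6-fold lower number from compound 2 to compound 4 (0.20 log units; within the scatter), slightly downward and within the scatter. For compound 4 the estimated half-life is 2.5 h, with an expected range of 1.2 h to 5 h.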

Compound 4, half-life: 3.2 h
Compound 4: the middle estimate sits 1.3-fold (0.11 log units) below what was measured; measured number inside the range.
By their numbers in this assay, from the lowest: compounds 1, 3, 4 and 2 (each within the scatter of the next).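

In this assay the place on an aromatic carbon between two ring nitrogen atoms now has a direct reading: putting 1H-imidazol-2-yl in place of dimethylcarbamoyl gives a 1.3-fold lower number from compound 2 to compound 4 (0.10 log units; within the scatter) and stays within the scatter. This place therefore accepts a ring in exchange for a group with no ring, with no clear shift in half-life. No available evidence bears on this result.

Going by these compounds, whether a carboxylic acid or an amine at this place would shift the half-life beyond the scatter remains open. So does the effect of altering the ring-borne group of 8 heavy atoms.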